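This account rests on a few compounds, and the source may have more. Where it says the series, first, only, none or still open, it means among the compounds named here.

Working notes on the series in a functional assay on HeLa cells (Homo sapiens) for cytotoxicity, read by MTT assay, with a stated time of 48 h; on this read-out lower numbers stand for stronger inhibition and higher numbers for weaker inhibition. Three measured compounds share one core. Compound 1 `Cc1nc2c3ccccc3ccc2c2nc3c(ccc4ccccc43)c(-c3cccc([N+](=O)[O-])c3)c12` gives 50700 nM in this assay. Compound 2 `Cc1nc2c3ccccc3ccc2c2nc3c(ccc4ccccc43)c(-c3cccnc3)c12` gives 3860 nM. Compound 3 `Cc1nc2c3ccccc3ccc2c2nc3c(ccc4ccccc43)c(-c3ccccc3N)c12` gives 16200 nM, the second highest of the three numbers; the step of a 3.1-fold lower number from compound 1 to compound 3 (0.50 log units; beyond the scatter) and the step of a 4.2-fold higher number from compound 2 to compound 3 (0.62 log units; beyond the scatter) place it between the other two. Compound 4 `Cc1nc2c3ccccc3ccc2c2nc3c(ccc4ccccc43)c(-c3ccccc3Cl)c12` is not yet measured; its change is chloro in place of amino on an aromatic carbon, ortho to a large group. Among the compounds with values here, no measured step swaps amino for chloro, so the only bearing comes from the spread of aryl variations: a 13-fold lower number from compound 1 to compound 2 (1.12 log units; beyond the scatter) is the widest, while the two steps reaching compound 3 are modest. A step of modest size in this assay is expected, a 1.4-fold lower number from compound 3 to compound 4 (0.13 log units; within the scatter). The estimate for compound 4 is 12000 nM, ranging from 4000 nM to 40000 nM.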

Compound 4, half-maximal inhibitory concentration: > 80000 nM
Compound 4: only a limit was reported; the forecaster's own chance of this, stated with the estimate: 5%; middle value at least 6.6-fold (0.82 log units) from the limit.
By their numbers in this assay, from the lowest: compound 2; then compound 3; then compound 1. At a limit, above all of these: compound 4.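

Compound 4 gives only a limit in this assay: the limit of > 80000 nM in this assay, at which 1 of the 4 values shown sits. Chloro in place of amino on this aromatic carbon, ortho to a large group, is therefore not a neutral swap (an at least 4.9-fold higher number from compound 3 to compound 4 (0.69 log units; beyond the scatter)), and 2-chlorophenyl also falls far behind pyridin-3-yl (an at least 20-fold higher number from compound 2 to compound 4 (1.31 log units; beyond the scatter)). The step from the 3-nitrophenyl analogue (an at least 1.5-fold higher number from compound 1 to compound 4 (0.19 log units; that floor lies within the scatter)) gives no firm order. On these data alone, whether a hydroxyl or a methyl group on this carbon would track amino or chloro remains open, as does how far compound 4 lies past its limit.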